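Hydroxy Replaces Carboxymethyl on the Amide Side Chain

The compounds below may be only part of what the source reports. "The series", "measured", "known", "first", "only" and "open" are said of these compounds alone.

compound 1 `O=C(O)CNC(=O)[C@]1(O)C[C@@H](O)[C@@H](O)[C@H](O)C1` — 38%
compound 2 `O=C(O)CC[C@H](NC(=O)[C@]1(O)C[C@@H](O)[C@@H](O)[C@H](O)C1)C(=O)O` — 43%

Of the compounds shown here, two have been measured in an assay on HL-60 cells for inhibition of E-selectin (Homo sapiens), tested at 50 mM; on this read-out lower numbers stand for less inhibition and higher numbers for more inhibition at the one concentration tested (going by the name of the read-out). Compound 1 `O=C(O)CNC(=O)[C@]1(O)C[C@@H](O)[C@@H](O)[C@H](O)C1` gives 38% in this assay, and compound 2 `O=C(O)CC[C@H](NC(=O)[C@]1(O)C[C@@H](O)[C@@H](O)[C@H](O)C1)C(=O)O` gives 43%. Within the data shown here, compound 2 holds the higher of the two numbers, with compound 1 as its only neighbour, but the single recorded step, a number 5 percentage points higher from compound 1 to compound 2 (within the scatter), lies within the scatter, so the two compounds cannot be ranked.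

Compound 3 `O=C(O)[C@H](CO)NC(=O)[C@]1(O)C[C@@H](O)[C@@H](O)[C@H](O)C1` has not yet been measured in this assay. It differs from compound 2 by hydroxy in place of carboxymethyl on a saturated chain carbon, two bonds along the chain from an amide-type nitrogen and a carbonyl carbon. Among the measured compounds shown here, the one measured step touches the same side chain: adding the 2-carboxyethyl group to compound 1 left the number within the scatter. For the measured compounds named here, nothing measured so far shows that the carboxyl on this side chain, or its replacement, moves the read-out, so no step beyond the scatter is expected here either.

Compound 3 is therefore estimated at 40%, within 28% to 52%. The expected step, a number 3 percentage points lower from compound 2 to compound 3 (within the scatter), stays within the scatter.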

Compound 3, a percentage reported as inhibition, at one concentration (the size of the read-out at that concentration, not a potency): 46%
Compound 3: the middle estimate sits 6 percentage points below what was measured; the range from low to high includes it.
By their numbers in this assay, from the lowest: compounds 1, 2 and 3 (each within the scatter of the next).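

In this assay, hydroxy in place of carboxymethyl on a saturated chain carbon, two bonds along the chain from an amide-type nitrogen and a carbonyl carbon, gives a number 3 percentage points higher from compound 2 to compound 3 (within the scatter), so this change, which removes the carboxylic acid at the end of the 2-carboxyethyl side chain, shows no measurable effect on the read-out. Hydroxymethyl in place of hydrogen at the same carbon gives a number 8 percentage points higher from compound 1 to compound 3 (within the scatter), and with a number 5 percentage points higher from compound 1 to compound 2 (within the scatter) this means that neither hydroxymethyl nor 2-carboxyethyl can be told apart from hydrogen at this place, although the earlier compounds had tested only the 2-carboxyethyl group. No independent measurement is available that bears on this result.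

The compounds shown leave open whether any group on this carbon can move the number beyond the scatter, for instance an amine such as aminomethyl, or a longer hydrocarbon chain. They also leave open whether the hydroxy groups on the shared core matter more to the read-out than this side chain does, as all three compounds carry the same core.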